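The compounds below may be only part of what the source reports. "The series", "measured", "known", "first", "only" and "open" are said of these compounds alone.

Compound 1, with the structure `COc1cc(-c2nnc3n2NC(c2cccs2)C(C(=O)c2ccc(C)cc2)S3)cc(OC)c1OC`, compound 2, with the structure `COc1cc(-c2nnc3n2NC(c2cccs2)C(C(=O)c2ccccc2)S3)cc(OC)c1OC`, and compound 3, with the structure `COc1cc(-c2nnc3n2NC(c2ccco2)C(C(=O)c2ccccc2)S3)cc(OC)c1OC`, were all tested in a functional assay on PC-3 cells (Homo sapiens) for cytotoxicity, read by MTT assay, with a stated time of 48 h; on this read-out lower numbers stand for stronger inhibition and higher numbers for weaker inhibition. In this assay compound 1 gives 5090 nM, compound 2 gives 86300 nM, and compound 3 gives 64300 nM. The change from compound 2 to compound 1 is methyl in place of hydrogen on an aromatic carbon, and the step it made in this assay is a 17-fold lower number from compound 2 to compound 1 (1.23 log units; beyond the scatter). The cores of compound 2 and compound 3 differ by furan-2-yl in place of thiophen-2-yl on a saturated ring carbon, and the step between them is a 1.3-fold lower number from compound 2 to compound 3 (0.13 log units; within the scatter), so these two compounds cannot be told apart on this read-out.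

Compound 4, with the structure `COc1cc(-c2nnc3n2NC(c2ccco2)C(C(=O)c2ccc(C)cc2)S3)cc(OC)c1OC`, has not yet been measured. Going by the values given here, it differs from compound 3 by methyl in place of hydrogen on an aromatic carbon, which is the same change as the one from compound 2 to compound 1, made this time on the core that carries furan-2-yl rather than thiophen-2-yl. The expectation for compound 4 rests on a single earlier instance of this change, namely the step of a 17-fold lower number from compound 2 to compound 1 (1.23 log units; beyond the scatter), and on the closeness of compound 3 to compound 2 in this assay. Among the compounds with values here, the step from compound 3 to compound 4 is therefore expected to be a 13-fold lower number from compound 3 to compound 4 (1.11 log units; beyond the scatter), somewhat smaller than the earlier one because only one example of it is known. Compound 4 is thus estimated to give 5000 nM in this assay, with a range from 1500 nM to 25000 nM.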

Compound 4, half-maximal inhibitory concentration: 7500 nM
Estimate against measurement, compound 4: 1.5-fold (0.18 log units) below, within the range that was stated.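

In this assay, methyl in place of hydrogen on an aromatic carbon lowers the number on the core that carries furan-2-yl as well, with an 8.6-fold lower number from compound 3 to compound 4 (0.93 log units; beyond the scatter), and this step agrees with the one seen on the core that carries thiophen-2-yl: the same change on two cores in this assay, a 17-fold lower number (1.23 log units; beyond the scatter) from compound 2 to compound 1 and an 8.6-fold lower number (0.93 log units; beyond the scatter) from compound 3 to compound 4, 2.0-fold (0.30 log units) apart, within the scatter of two such steps. The exchange of thiophen-2-yl for furan-2-yl likewise gives the same picture with the methyl group present as without it, with a 1.5-fold higher number from compound 1 to compound 4 (0.17 log units; within the scatter), so neither pair separated by that exchange can be told apart on this read-out: the same change on two cores in this assay, a 1.3-fold lower number (0.13 log units; within the scatter) from compound 2 to compound 3 and a 1.5-fold higher number (0.17 log units; within the scatter) from compound 1 to compound 4, 2.0-fold (0.30 log units) apart, within the scatter of two such steps. This shows that the methyl step carried over between these two closely matched cores, but it rests on only two instances, and it does not show that the step would hold on a core with any other group in place of thiophen-2-yl or furan-2-yl, or why the methyl group lowers the number.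

The compounds shown carry only hydrogen or methyl at this place on the six-membered aromatic ring, so it remains open whether an ethyl group, a methoxy group or a chlorine atom there would give a step of similar size. Going by these compounds, it also remains open how an amine or a carboxylic acid on that ring would behave in this assay.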